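Hydroxymethyl for Bromo on Two Sites of a Fused Core

This account rests on a few compounds, and the source may have more. Where it says the series, first, only, none or still open, it means among the compounds named here.

In an ADME assay on HEK-293T cells (Homo sapiens) for cytotoxicity, read by luminescence, with a stated time of 24 h (a lower number here means that less compound is tolerated, a higher number that more compound is tolerated), compound 1 `CCCNC(=O)C1CCN(C(=O)c2cc3sc(Br)cc3n2Cc2ccc(OC)cc2)CC1` gives only a limit, > 100000 nM.
Compound 2 `CCCNC(=O)C1CCN(C(=O)c2cc3sc(CO)cc3n2Cc2ccc(OC)cc2)CC1` gives 15500 nM in this assay.
Compound 3 `CCCNC(=O)C1CCN(C(=O)c2c(Br)c3sccc3n2Cc2ccc(OC)cc2)CC1` gives 31600 nM in this assay.

The step from compound 1 to compound 2 is hydroxymethyl in place of bromo on an aromatic carbon, and it brought an at least 6.4-fold lower number from compound 1 to compound 2 (0.80 log units; beyond the scatter), its full size hidden by the limit of > 100000 nM in this assay, at which 1 of the 3 values shown sits. Compound 3 shares its atoms with compound 1, joined differently; the difference between the two cores is not broken down here. Compound 4 `CCCNC(=O)C1CCN(C(=O)c2c(CO)c3sccc3n2Cc2ccc(OC)cc2)CC1` differs from compound 3 by hydroxymethyl in place of bromo on an aromatic carbon, the same kind of change, though here the place is on the ring with one nitrogen rather than next to the ring sulfur. From compound 3 to compound 4 she expects a 3.2-fold lower number from compound 3 to compound 4 (0.50 log units; beyond the scatter) in this assay, resting on an at least 6.4-fold lower number from compound 1 to compound 2 (0.80 log units; beyond the scatter). Compound 4 is estimated at 10000 nM, between 3000 nM and 40000 nM.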

Compound 4, half-maximal cytotoxic concentration: > 100000 nM
Compound 4: a limit, no number; the forecaster's own chance of this, stated with the estimate: 5%; middle value at least 10-fold (1.00 log units) from the limit.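

In this assay, hydroxymethyl in place of bromo on an aromatic carbon brought an at least 3.1-fold higher number from compound 3 to compound 4 (0.50 log units; beyond the scatter), so the change did not carry its direction from one core to the other: the same change on two cores in this assay, an at least 6.4-fold lower number (0.80 log units; beyond the scatter) from compound 1 to compound 2 and an at least 3.1-fold higher number (0.50 log units; beyond the scatter) from compound 3 to compound 4, at least 20-fold (1.30 log units) apart, beyond the scatter of two such steps. Compound 1 and compound 4 each give a limit and not a number, so neither step has a known full size: the limit of > 100000 nM in this assay, at which 2 of the 4 values shown sit. The two steps show that this change cannot be assumed to transfer between these two cores, but they do not show what in the cores sets the direction.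

The compounds shown leave open how an aminomethyl group or a carboxylic acid in place of bromo would read on either core. They also leave open whether a longer chain such as hydroxyethyl would follow hydroxymethyl.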